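A few compounds are considered here, and "the series" means these few. Any claim that something is new, unique, unknown or untested is made for them only; others in the source may bear on it.

In a functional assay on HEK293 cells for positive allosteric modulation of metabotropic glutamate receptor 5 (Rattus norvegicus), read by fluorescence and calcium flux (on this read-out lower numbers stand for smaller maximal responses and higher numbers for larger maximal responses), compound 2 `CC(C)[C@H](C)NC(=O)c1ccc(C#Cc2cccc(F)c2)cn1` gives 66.7%. Among the compounds with values here, the only other measured compound, compound 1 `C[C@@H](NC(=O)c1ccc(C#Cc2cccc(F)c2)nn1)C(C)(C)O`, gives 70.2% in this assay; the two numbers lie within the usual scatter of each other, so compound 2 cannot be set apart from compound 1 on this read-out, and no step between the two has been worked out. Compound 3 `CC(C)(CO)NC(=O)c1ccc(C#Cc2cccc(F)c2)cn1` has not yet been measured. It differs from compound 2 in one place: 1-(hydroxymethyl)-1-methylethyl in place of 1,2-dimethylpropyl on an amide-type nitrogen. The group that enters brings one hydrogen-bond donor and one hydrogen-bond acceptor, where the group that leaves has none. Within the data shown here, nothing among the measured pair shows how such an exchange moves the largest response reached, so for compound 3 a step of a number 1.7 percentage points lower from compound 2 to compound 3 (within the scatter) is expected, one that stays within the scatter. Compound 3 is accordingly estimated at 65%, with a range from 50% to 80%.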

Compound 3, largest response reached (reported as efficacy), in percent of the reference or control that the assay uses: 60.9%
Compound 3: the middle estimate sits 4.1 percentage points above what was measured, and the stated range covers the measured number.
By their numbers in this assay, from the lowest: compounds 3, 2 and 1 (each within the scatter of the next).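

In this assay, the exchange of 1,2-dimethylpropyl for 1-(hydroxymethyl)-1-methylethyl on an amide-type nitrogen comes out as a number 5.8 percentage points lower from compound 2 to compound 3 (within the scatter). Within the data shown here, this is the first single-place comparison, and it shows that the largest response reached cannot be told apart between the two groups, even though the entering group carries a hydrogen-bond donor and acceptor and the leaving group has neither, and the defined stereocentre of the leaving group is gone. Nothing available explains the size of this step.

As far as these compounds go, it remains open whether an amine, a carboxylic acid or a longer chain on this amide-type nitrogen would give a step beyond the scatter. From the compounds shown here alone, it also remains open whether the same exchange would give a similar step on the core of compound 1.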